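Isoflavone ethers: terminal acid to terminal hydroxyl

The source may report more compounds than this note shows. Statements on the series, on what has been measured and on what is new or still open speak of the compounds shown alone.

Three isoflavone ethers have numbers in an assay (Cricetulus griseus) for inhibition of aldehyde dehydrogenase, mitochondrial (Homo sapiens); on this read-out higher numbers stand for weaker inhibition and lower numbers for stronger inhibition. Compound 1 `CCCCC(Oc1ccc2c(=O)c(-c3ccc(O)cc3)coc2c1)C(=O)OCC` gives 4500 nM in this assay. Compound 3 `CCCCCCC(Oc1ccc2c(=O)c(-c3ccc(O)cc3)coc2c1)C(=O)O` gives 2000 nM in this assay. Compound 2 `O=C(O)CCCCCCOc1ccc2c(=O)c(-c3ccc(O)cc3)coc2c1` gives 50 nM in this assay, the lowest of the three numbers; its gap to compound 3 and its larger gap to compound 1 both lie beyond the usual scatter. Compound 2 is the only one of the three that carries a free carboxylic acid on a straight chain; compound 3 carries its acid on a branched chain and compound 1 carries an ester.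

Compound 4 `O=c1c(-c2ccc(O)cc2)coc2cc(OCCOCCOCCO)ccc12` has not been measured in this assay. It differs from compound 2 in one place: 2-(2-hydroxyethoxy)ethoxy in place of 4-carboxybutyl on a saturated chain carbon, two bonds along the chain from an oxygen on an aromatic ring. The acid of compound 2 is replaced by a hydroxyl at the end of an ether chain, with two ether oxygens added along the way.

Among the measured compounds shown here, no measured pair isolates this exchange, so the step from compound 2 to compound 4 is uncertain. The expectation is a step toward weaker inhibition, a 12-fold higher number from compound 2 to compound 4 (1.08 log units; beyond the scatter), because compound 2 at 50 nM stands apart from compound 3 at 2000 nM and compound 1 at 4500 nM, which both lack its straight-chain acid. Compound 4 is estimated at 600 nM, with a range from 120 nM to 3000 nM.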

Compound 4, half-maximal inhibitory concentration: 40 nM
Estimate against measurement, compound 4: 15-fold (1.18 log units) above; measured number outside the range, below it.
By their numbers in this assay, from the lowest: compounds 4 and 2 (each within the scatter of the next); then compound 3; then compound 1.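

In this assay the exchange of 4-carboxybutyl for 2-(2-hydroxyethoxy)ethoxy, on a saturated chain carbon, two bonds along the chain from an oxygen on an aromatic ring, is a 1.3-fold lower number from compound 2 to compound 4 (0.10 log units; within the scatter). Compound 4 ends in a hydroxyl and has no carboxylic acid, yet gives 40 nM, so a number at this level at this position does not depend on a terminal acid; compounds 1 and 3 could not show this, as neither forms a one-place pair with compound 2. Two chains with the same count of heavy atoms, one all carbon up to its acid and the other carrying ether oxygens, thus read alike here, and no supporting measurement on hand accounts for that.

As far as these compounds go, whether the end group matters at all stays open: a methyl ether or an amine in place of the terminal hydroxyl of compound 4 would test it. Also open, from the compounds shown here alone, is how far the chain length can move at this position, with a shorter or a longer ether chain on the same core.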